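Dropping the Iodine from Compound 1

A few compounds are considered here, and "the series" means these few. Any claim that something is new, unique, unknown or untested is made for them only; others in the source may bear on it.

Going by the values given here, compound 1 `O=C1C=C(Nc2ccc(I)cc2)C(=O)c2c1nc1n2[C@H]2OC[C@@H](O)[C@H]2OC1` is the only one of three compounds to give a number in a functional assay on HeLa cells (Homo sapiens) for inhibition, read by sulforhodamine B assay; on this read-out lower numbers stand for stronger inhibition and higher numbers for weaker inhibition: compound 1 gives 4070 nM. Compound 2 `COc1ccc(NC2=CC(=O)c3c(nc4n3[C@H]3OC[C@@H](O)[C@H]3OC4)C2=O)cc1` reaches only a limit of the assay in this assay, namely > 8000 nM. Compound 3 `O=C1C(N2CCCCC2)=CC(=O)c2c1nc1n2[C@H]2OC[C@@H](O)[C@H]2OC1` likewise stops at a limit, namely > 16000 nM. The step that the two limits leave unreadable from compound 2 to compound 3 therefore cannot be read, because the limit of > 8000 nM in this assay, at which 1 of the 3 values shown sits, and the limit of > 16000 nM in this assay, at which 1 of the 3 values shown sits, hide its size. Among the compounds with values here, compound 4 `O=C1C=C(Nc2ccccc2)C(=O)c2c1nc1n2[C@H]2OC[C@@H](O)[C@H]2OC1` differs from compound 1 by hydrogen in place of iodo on an aromatic carbon, a change that none of the measured steps covers. With no measured guide, the step of a 1.5-fold higher number from compound 1 to compound 4 (0.17 log units; within the scatter) is expected to stay within the usual scatter, though the range is kept wide. Compound 4 is thus estimated at 6000 nM, between 2000 nM and 16000 nM.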

Compound 4, half-maximal inhibitory concentration: 5620 nM
Compound 4: middle estimate off by 1.1-fold (0.03 log units), on the high side; measured number inside the range.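

Replacing the iodo of the 4-iodophenyl group with hydrogen gives, in this assay, a 1.4-fold higher number from compound 1 to compound 4 (0.14 log units; within the scatter). On this evidence, the iodine on this six-membered aromatic ring is not needed for the activity seen in compound 1, and the plain anilino compound 4 stays level with it. No measurement shown here explains this result.

As far as these compounds go, whether a different group at this carbon, such as an amine or a carboxylic acid, would shift the number remains open. So does the effect of a longer chain on the nitrogen of the anilino group.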